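This account rests on a few compounds, and the source may have more. Where it says the series, first, only, none or still open, it means among the compounds named here.

Series notes. Compound 1 `COC(=O)C1=C(C)NC(=O)NC1c1cccc([N+](=O)[O-])c1` is the parent of the set and in an assay on HEK293 cells for antagonist activity at Voltage-dependent L-type calcium channel subunit alpha-1C (Oryctolagus cuniculus), read by FLIPR (on this read-out higher numbers stand for weaker inhibition and lower numbers for stronger inhibition), compound 1 gives 11700 nM. Compound 3 `COC(=O)C1=C(C)NC(=O)N(C(=O)OC(C)C)C1c1cccc([N+](=O)[O-])c1` carries one change on the shared core, (isopropoxycarbonyl in place of hydrogen on an amide-type nitrogen in a ring), and in this assay compound 3 gives 2480 nM, a step of a 4.7-fold lower number from compound 1 to compound 3 (0.67 log units; beyond the scatter). Compound 2 `COC(=O)C1=C(C)NC(=S)NC1c1cccc([N+](=O)[O-])c1` is the second core; the difference between the two cores is not broken down here, and in this assay compound 2 gives 55000 nM, the highest of the three numbers measured. Compound 4 `COC(=O)C1=C(C)NC(=S)N(C(=O)OC(C)C)C1c1cccc([N+](=O)[O-])c1` is not yet measured; it differs from compound 2 by isopropoxycarbonyl in place of hydrogen on an amide-type nitrogen in a ring, the same change as that from compound 1 to compound 3, at the same place. Among the measured compounds shown here, for compound 4 a step of a 4.6-fold lower number from compound 2 to compound 4 (0.66 log units; beyond the scatter) is expected, resting on the single earlier example a 4.7-fold lower number from compound 1 to compound 3 (0.67 log units; beyond the scatter). In this assay compound 4 is therefore estimated at 12000 nM, with the range 4000 nM to 35000 nM.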

Compound 4, half-maximal inhibitory concentration: 170 nM
For compound 4 the middle estimate is 71-fold (1.85 log units) above the measured one; the measured number lies below the stated range.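

Isopropoxycarbonyl in place of hydrogen on the amide-type nitrogen lowers the number on both cores in this assay, so the direction carries over but the size does not, with a 320-fold lower number from compound 2 to compound 4 (2.51 log units; beyond the scatter) set against the earlier step: the same change on two cores in this assay, a 4.7-fold lower number (0.67 log units; beyond the scatter) from compound 1 to compound 3 and a 320-fold lower number (2.51 log units; beyond the scatter) from compound 2 to compound 4, 69-fold (1.84 log units) apart, beyond the scatter of two such steps A step read on one core is therefore a poor guide to its size on the other in this series. These two pairs give a single comparison, and they do not show what sets the gap between the steps or whether it would hold for other groups.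

On these data alone, whether an acetyl group or a longer chain on the same nitrogen would show a similar gap between the two cores stays open.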